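The source may hold more compounds than are shown below. What is called first, only, known or untested is meant among the compounds shown, and "the series" means these compounds.

Of the compounds shown here, three sharing one core have been measured in an assay on HEK293 cells for agonist activity at Toll-like receptor 8 (Homo sapiens), read by a luciferase reporter, with a stated time of 6 h; on this read-out lower numbers stand for an effect already at smaller amounts and higher numbers for an effect only at larger amounts of compound. Compound 1 `CCCCNc1nc(N)nc2c1CN(Cc1ccccc1)CC2` gives 0.06 uM. Compound 2 `CCCCNc1nc(N)nc2c1CN(C(C)=O)CC2` gives 0.5 uM, and compound 3 `CCCCNc1nc(N)nc2c1CN(C(=O)c1cnc(C)cn1)CC2` gives 6.8 uM. The change an 8.3-fold higher number from compound 1 to compound 2 (0.92 log units; beyond the scatter) and the further change a 14-fold higher number from compound 2 to compound 3 (1.13 log units; beyond the scatter) both moved the number upward, so compound 3 stands highest of the three, with compound 2 nearest to it and compound 1 furthest away.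

Compound 4 `CCCCNc1nc(N)nc2c1CN(C(=O)c1csc(N)n1)CC2` has not yet been measured. It differs from compound 3 in one place: 2-amino-1,3-thiazol-4-yl in place of 5-methylpyrazin-2-yl on a carbonyl carbon. Among the compounds with values here, the only measured step at this carbonyl carbon is a 14-fold higher number from compound 2 to compound 3 (1.13 log units; beyond the scatter), which put an aromatic ring where a small group had been. Within the data shown here, no measured step swaps one aromatic ring for another on the carbonyl, which is what happens here. The step of an 8.3-fold higher number from compound 1 to compound 2 (0.92 log units; beyond the scatter) concerns the amine nitrogen in the ring rather than the carbonyl and bears little on the question. Since compound 3 and compound 4 both carry an aromatic ring on the carbonyl, the expected step of a 1.0-fold higher number from compound 3 to compound 4 (0.01 log units; within the scatter) is none beyond the scatter, though the new hydrogen-bond donor leaves room for movement in either direction. Compound 4 is therefore expected to give about 7 uM, within a range of 2 uM to 30 uM.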

Compound 4, minimum effective concentration: 6.9 uM
Compound 4: middle estimate off by 1.0-fold (0.01 log units), on the high side; the range from low to high includes it.
By their numbers in this assay, from the lowest: compound 1; then compound 2; then compounds 3 and 4 (each within the scatter of the next).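

In this assay, putting the five-membered 2-amino-1,3-thiazol-4-yl on the carbonyl carbon in place of the six-membered 5-methylpyrazin-2-yl gives a 1.0-fold higher number from compound 3 to compound 4 (0.01 log units; within the scatter), so this position shows no measurable response to a swap that changes the ring size, the ring atoms and the number of hydrogen-bond donors. The earlier rise from the methyl group is therefore not unique to one ring: the new ring gives a 14-fold higher number from compound 2 to compound 4 (1.14 log units; beyond the scatter), and its whole acyl group in place of benzyl on the amine nitrogen in the ring gives a 120-fold higher number from compound 1 to compound 4 (2.06 log units; beyond the scatter). No independent data here show why these two different rings read alike.

The compounds shown leave open whether the rise from methyl requires an aromatic ring at all, a question that a cyclohexyl ring or a butyl chain on the carbonyl carbon could address. Going by these compounds, it also remains open whether compound 1 reaches 0.06 uM through its phenyl ring or through the absence of a carbonyl, which an ethyl group on the same nitrogen or a phenylacetyl group could help to separate.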